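Compound 3 to compound 4: a larger amide side group

A few compounds are considered here, and "the series" means these few. Any claim that something is new, unique, unknown or untested is made for them only; others in the source may bear on it.

Three compounds share one core and differ in the group on a saturated chain carbon bound to an aromatic carbon. In a functional assay on HeLa cells (Homo sapiens) for antiproliferative activity, read by CCK-8 assay, with a stated time of 48 h (a higher number here means a weaker inhibitor, a lower number a stronger inhibitor), compound 1 `COc1ccc(/C=C\c2cc(OC)c(OC)c(OC)c2)cc1OCc1ccc(CN2CCCC[C@@H]2C(=O)O)cc1` gives > 10000 nM, which is a limit of the assay and not a number. Compound 2 `COc1ccc(/C=C\c2cc(OC)c(OC)c(OC)c2)cc1OCc1ccc(CN[C@H](C(=O)O)[C@H](C)O)cc1` gives > 10000 nM in this assay, again a limit. Within the data shown here, compound 3 `COc1ccc(/C=C\c2cc(OC)c(OC)c(OC)c2)cc1OCc1ccc(CN2CC[C@H](O)C2)cc1` gives 10500 nM, the only actual number, so it has no measured neighbour to be ranked against. The picture so far is set by the limit of > 10000 nM in this assay, at which 2 of the 3 values shown sit.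

Compound 4 `COc1ccc(/C=C\c2cc(OC)c(OC)c(OC)c2)cc1OCc1ccc(CN2CCCCC2C(=O)NCCN)cc1` is reached from compound 3 by 2-((2-aminoethyl)carbamoyl)piperidin-1-yl in place of 3-hydroxypyrrolidin-1-yl on a saturated chain carbon bound to an aromatic carbon. The entering group keeps the piperidine of the 2-carboxypiperidin-1-yl group in compound 1, but the carboxyl gives way to a (2-aminoethyl)carbamoyl.

Among the measured compounds shown here, three measured steps bear on this change: a step that the two limits leave unreadable from compound 1 to compound 2, a step that the limit leaves unreadable from compound 1 to compound 3 and a step that the limit leaves unreadable from compound 2 to compound 3. None has a readable size, so none can be carried over. No step beyond the scatter is therefore expected in this assay, and no direction is firmly expected; the expectation rests on compound 3 at 10500 nM. Estimated as a step, this is a 1.8-fold lower number from compound 3 to compound 4 (0.24 log units; within the scatter). For compound 4 the expected value is 6000 nM, with an estimated range from 1000 nM to 20000 nM.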

Compound 4, half-maximal inhibitory concentration: 7300 nM
The estimate for compound 4 lay 1.2-fold (0.09 log units) below the measured number; low and high end bracket the measured number.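

In this assay, among these compounds, the first step with a readable size is a 1.4-fold lower number from compound 3 to compound 4 (0.16 log units; within the scatter), so on a saturated chain carbon bound to an aromatic carbon, 2-((2-aminoethyl)carbamoyl)piperidin-1-yl, with 12 heavy atoms, cannot be told apart from 3-hydroxypyrrolidin-1-yl, with 6. Against the two carboxyl-bearing groups, the result gives an at least 1.3-fold lower number from compound 2 to compound 4 (0.13 log units; that floor lies within the scatter) and an at least 1.3-fold lower number from compound 1 to compound 4 (0.13 log units; that floor lies within the scatter), so neither comparison shows a step beyond the scatter. Those two steps remain floors, and the steps among compound 1, compound 2 and compound 3 still cannot be read, because of the assay limit: the limit of > 10000 nM in this assay, at which 2 of the 4 values shown sit.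

The compounds shown leave open what the terminal amine of the (2-aminoethyl)carbamoyl group contributes, a question that a methylcarbamoyl group or a longer aminopropyl chain on the same piperidine would address. Also open, from the compounds shown here alone, is whether a morpholine or a dimethylamino group at this place would move the number beyond the scatter from that of compound 3, which gives 10500 nM.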